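Chloro in Place of Hydrogen: What Compound 4 Might Show

A few compounds are considered here, and "the series" means these few. Any claim that something is new, unique, unknown or untested is made for them only; others in the source may bear on it.

Compound 1 `Cc1cc(O)c(C(C)C)cc1-c1cc(-c2ccccc2)c(C#N)c(=O)[nH]1` gives 22% in a functional assay for inhibition, tested at 20 ug/mL; on this read-out higher numbers stand for a stronger effect at the one concentration tested and lower numbers for a weaker effect. Compound 2 `COc1cccc(-c2cc(-c3cc(C(C)C)c(O)cc3C)[nH]c(=O)c2C#N)c1` gives 22%, and compound 3 `Cc1cc(O)c(C(C)C)cc1-c1cc(-c2ccccc2[N+](=O)[O-])c(C#N)c(=O)[nH]1` gives 20%. Compound 1 thus stands level with compound 2 at the digits shown, the two together the highest of the three numbers, with compound 3 nearest below; the step of a number 2 percentage points lower from compound 2 to compound 3 (within the scatter) lies within the scatter. Compound 4 `Cc1cc(O)c(C(C)C)cc1-c1cc(-c2ccccc2Cl)c(C#N)c(=O)[nH]1` differs from compound 1 by chloro in place of hydrogen on an aromatic carbon. The most relevant earlier step is a number 2 percentage points lower from compound 1 to compound 3 (within the scatter), because the step of a number 2 percentage points lower from compound 1 to compound 3 (within the scatter) also brought a new substituent onto the same core where compound 1 carries only hydrogen; the step of no change at the digits printed from compound 1 to compound 2 (within the scatter) was likewise small. Compound 4 is therefore expected to show no step beyond the scatter, a number 2 percentage points lower from compound 1 to compound 4 (within the scatter). Compound 4 is estimated at 20%, between 10% and 32%.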

Compound 4, a percentage reported as inhibition, at one concentration (the size of the read-out at that concentration, not a potency): 12%
Compound 4: middle estimate off by 8 percentage points, on the high side, and the stated range covers the measured number.
By their numbers in this assay, from the lowest: compounds 4, 3, 1 and 2 (each within the scatter of the next).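

In this assay, chloro on an aromatic carbon ortho to a large group gives a number 10 percentage points lower from compound 1 to compound 4 (within the scatter), the widest step yet seen from compound 1, though still not one that can be told from the scatter. Chloro in place of nitro reads a number 8 percentage points lower from compound 3 to compound 4 (within the scatter), and 2-chlorophenyl in place of 3-methoxyphenyl reads a number 10 percentage points lower from compound 2 to compound 4 (within the scatter), so none of the four compounds is set apart from the others. Nothing at hand explains these numbers.

On these data alone, whether an amine or a carboxylic acid at this place would give a step beyond the scatter stays open. So does the effect of chloro on another carbon of this ring.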